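Isopropyl for methyl on a core already at the limit

The source may report more compounds than this note shows. Statements on the series, on what has been measured and on what is new or still open speak of the compounds shown alone.

Compound 3 `CC1CC(=O)c2s/c(=N/c3c(Cl)cc(Cl)cc3Cl)oc2C1` was tested in a functional assay on PC-3 cells (Homo sapiens) for antiproliferative activity, read by sulforhodamine B assay; on this read-out higher numbers stand for weaker inhibition of growth and lower numbers for stronger inhibition of growth. In this assay compound 3 reaches only the limit of the measurement, > 30000 nM. Compound 2 `CC1(C)CC(=O)c2s/c(=N/c3c(Cl)cc(Cl)cc3Cl)oc2C1` likewise stops at a limit in this assay, > 30000 nM. The step that the two limits leave unreadable from compound 2 to compound 3 therefore says nothing about how much a methyl on that ring carbon matters. Compound 1 `CC1(C)CC(=O)c2s/c(=N/c3ccc(Cl)cc3)oc2C1` gives 4260 nM in this assay. Compound 4 `CC(C)C1CC(=O)c2s/c(=N/c3c(Cl)cc(Cl)cc3Cl)oc2C1` differs from compound 3 by isopropyl in place of methyl on a saturated ring carbon. Going by the values given here, no measured step bears on that change, and both nearest relatives sit at the limit of > 30000 nM in this assay, at which 2 of the 3 values shown sit. Compound 4 is therefore expected to stay at or near that limit, with the step that the limit leaves unreadable from compound 3 to compound 4 estimated as no real change. The estimate for compound 4 is 40000 nM, within 12000 nM to 150000 nM.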

Compound 4, concentration for 50% growth inhibition: > 30000 nM
Compound 4 was reported as a limit (the forecaster's own chance of this, stated with the estimate: 75%); the middle value does not contradict the limit.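

Compound 3 and compound 4 both stop at a limit of the measurement, so no step between them can be read: the limit of > 30000 nM in this assay, at which 3 of the 4 values shown sit.

Going by these compounds, how much isopropyl or methyl on that saturated ring carbon matters for inhibition of growth stays open.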